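Swapping a nitrophenyl amide for an acetyl amide

The source may report more compounds than this note shows. Statements on the series, on what has been measured and on what is new or still open speak of the compounds shown alone.

In a functional assay on MCF7 cells (Homo sapiens) for cytotoxicity, read by MTT assay, with a stated time of 48 h (a lower number here means a stronger inhibitor, a higher number a weaker inhibitor), compound 1 `CC(=O)Nc1ccc2nc(SCC(=O)NCc3ccc(Cl)cc3)sc2c1` gives 10200 nM. Compound 3 `O=C(CSc1nc2ccc(NC(=O)c3ccc([N+](=O)[O-])cc3)cc2s1)NCc1ccc(Cl)cc1` reaches only a limit of the test, > 100000 nM. Compound 2 `CNC(=O)CSc1nc2ccc(NC(=O)c3ccc([N+](=O)[O-])cc3)cc2s1` likewise reaches only a limit of the test, > 100000 nM. The change from compound 3 to compound 1 is methyl in place of 4-nitrophenyl on a carbonyl carbon, and it brings an at least 9.8-fold lower number from compound 3 to compound 1 (0.99 log units; beyond the scatter). The cores of compound 2 and compound 3 differ by hydrogen in place of 4-chlorophenyl on a saturated chain carbon bound to an amide-type nitrogen; here the result is a step that the two limits leave unreadable from compound 2 to compound 3 because of the limit of > 100000 nM in this assay, at which 2 of the 3 values shown sit. Compound 4 `CNC(=O)CSc1nc2ccc(NC(C)=O)cc2s1` has not yet been measured; it differs from compound 2 by methyl in place of 4-nitrophenyl on a carbonyl carbon, the same change that turned compound 3 into compound 1. The step is expected to be an at least 3.3-fold lower number from compound 2 to compound 4 (0.52 log units; beyond the scatter), resting on the earlier step of an at least 9.8-fold lower number from compound 3 to compound 1 (0.99 log units; beyond the scatter). Compound 4 is therefore estimated at 30000 nM.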

Compound 4, half-maximal inhibitory concentration: > 100000 nM
Compound 4 gave a limit, no number; the forecaster's own chance of this, stated with the estimate: 35%; middle value at least 3.3-fold (0.52 log units) from the limit.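

In this assay compound 4 gives > 100000 nM and this is a limit of the test, not a number. The drop seen when methyl replaced 4-nitrophenyl on the carbonyl carbon of compound 3 therefore cannot be confirmed or ruled out on the core of compound 2, and the steps among the compounds at this limit cannot be read: the limit of > 100000 nM in this assay, at which 3 of the 4 values shown sit. Within the data shown here, the one readable new step, for hydrogen in place of 4-chlorophenyl on the saturated chain carbon, is an at least 9.8-fold higher number from compound 1 to compound 4 (0.99 log units; beyond the scatter) and shows that the methyl change gave a measurable value only with 4-chlorophenyl present, though it gives no cause for this.

The compounds shown leave open how much of the 4-chlorophenyl group is needed. They also leave open whether a carboxylic acid or an amine in its place would keep a measurable value.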